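A few compounds are considered here, and "the series" means these few. Any claim that something is new, unique, unknown or untested is made for them only; others in the source may bear on it.

Three compounds have been measured in a functional assay on A-375 cells (Homo sapiens) for antiproliferative activity, read by CCK-8 assay, with a stated time of 72 h, tested at 2 uM; a lower number here means a weaker effect, a higher number a stronger effect of the compound at the concentration tested:

Compound 1 `Nc1ccccc1NC(=O)c1ccc(CSC(=S)N2CCN(c3ccc(Cl)cc3)CC2)cc1` — 32.2%
Compound 2 `Nc1ccccc1NC(=O)c1ccc(CSC(=S)N2CCc3cc(Cl)ccc32)cc1` — 31.9%
Compound 3 `Nc1ccccc1NC(=O)c1ccc(CSC(=S)N(Cc2ccccc2)Cc2ccccc2)cc1` — 10.9%

Compound 1 has the highest of the three numbers. Compound 2 lies within the usual scatter of it, so the two cannot be told apart on these data. Compound 3 is the furthest away, and its number is lower by more than the scatter, so it does show a weaker effect than compound 1. Among the measured compounds shown here, no two measured compounds differ in just one place, so no single structural step has been quantified directly.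

Compound 4 `Nc1ccccc1NC(=O)c1ccc(CSC(=S)N2CCN(c3ccccc3F)CC2)cc1` is not yet measured. It differs from compound 1 in one place: 2-fluorophenyl in place of 4-chlorophenyl on an amine nitrogen in a ring. The measured set holds no comparable exchange on this nitrogen, so there is nothing to calibrate the move against. The step expected for this assay is therefore taken as small, at most a slight fall, and not clearly beyond the scatter. The step of a number 4.2 percentage points lower from compound 1 to compound 4 (within the scatter) is the one expected here. Compound 4 is thus estimated at 28%, within a range of 15% to 42%.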

Compound 4, a percentage reported as inhibition, at one concentration (the size of the read-out at that concentration, not a potency): 18.7%
Beside the measured number, compound 4's estimate is 9.3 percentage points above it, and the stated range covers the measured number.
By their numbers in this assay, from the lowest: compounds 3 and 4 (each within the scatter of the next); then compounds 2 and 1 (each within the scatter of the next).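

In this assay, among the compounds shown here, the exchange of 4-chlorophenyl for 2-fluorophenyl on the amine nitrogen in the ring gives the first single change that can be read, and it gives a number 13.5 percentage points lower from compound 1 to compound 4 (beyond the scatter). The two groups match in everything counted for them apart from the halogen, with the same heavy-atom count and no hydrogen-bond donors or acceptors, yet the read-out at this concentration still responds to the exchange, so this position is sensitive to the aryl group it carries. No measurement at hand accounts for this step.

The exchange alters both the halogen and its place on the phenyl ring, and the compounds shown do not separate the two. Neither 4-fluorophenyl, 2-chlorophenyl nor an unsubstituted phenyl on this nitrogen appears among them.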